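Removing a tert-butoxycarbonyl Cap from a Fluorinated Polyamine

The source may hold more compounds than are shown below. What is called first, only, known or untested is meant among the compounds shown, and "the series" means these compounds.

Four polyamines built on two related cores were studied. Compound 1, `CC(C)(C)OC(=O)NCCCCNCCCN(Cc1ccccc1)Cc1ccccc1`, and compound 2, `CC(C)(C)OC(=O)NCCCCNCCCN(Cc1ccc(F)cc1)Cc1ccc(F)cc1`, carry a tert-butoxycarbonyl cap on one amine nitrogen; the difference between the two cores is not broken down here. In an ADME assay on RAW264.7 cells (Mus musculus) for cytotoxicity, read by resazurin assay, with a stated time of 48 h (on this read-out higher numbers stand for lower toxicity in this test and lower numbers for higher toxicity in this test), compound 1 gives 12500 nM and compound 2 gives 8700 nM, numbers that sit within the usual scatter of each other. Compound 3, `NCCCCNCCCN(Cc1ccccc1)Cc1ccccc1`, is compound 1 without the cap: hydrogen in place of tert-butoxycarbonyl on an amine nitrogen. In this assay compound 3 gives 17700 nM, which is a 1.4-fold higher number from compound 1 to compound 3 (0.15 log units; within the scatter).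

Compound 4, `NCCCCNCCCN(Cc1ccc(F)cc1)Cc1ccc(F)cc1`, stands to compound 2 exactly as compound 3 stands to compound 1: hydrogen in place of tert-butoxycarbonyl on an amine nitrogen. The place is described in the same words in both cases, so this is the same change made on the second core. Because the measured step of a 1.4-fold higher number from compound 1 to compound 3 (0.15 log units; within the scatter) stayed within the scatter, a small step is expected here too, a 1.4-fold higher number from compound 2 to compound 4 (0.14 log units; within the scatter). Compound 4 is therefore expected to give about 12000 nM in this assay, with a likely range from 6000 nM to 24000 nM.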

Compound 4, half-maximal cytotoxic concentration: 33100 nM
For compound 4 the middle estimate is 2.8-fold (0.44 log units) below the measured one; measured number above the stated range.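

Removing the tert-butoxycarbonyl cap in this assay gives a 3.8-fold higher number from compound 2 to compound 4 (0.58 log units; beyond the scatter), so on this core the change moves the number towards lower toxicity in this test by more than the usual scatter. The size of the step does not carry over unchanged from one core to the other: the same change on two cores in this assay, a 1.4-fold higher number (0.15 log units; within the scatter) from compound 1 to compound 3 and a 3.8-fold higher number (0.58 log units; beyond the scatter) from compound 2 to compound 4, 2.7-fold (0.43 log units) apart, beyond the scatter of two such steps. These two pairs show that a step measured on one core can be a poor guide to the same change on the other, but they do not show why the two cores differ or how the change would behave on any further core.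

The compounds shown leave open whether a different cap on the same amine nitrogen, such as an acetyl group, would give a step like that of tert-butoxycarbonyl. They also leave open whether the larger step would persist with a chlorine atom in place of each fluorine atom on the core of compound 4, or with a longer chain between the amine nitrogens.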